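A few compounds are considered here, and "the series" means these few. Any claim that something is new, unique, unknown or untested is made for them only; others in the source may bear on it.

Measured so far in a functional assay on A549 cells (Homo sapiens) for cytotoxicity, read by MTT assay, with a stated time of 72 h; on this read-out lower numbers stand for stronger inhibition and higher numbers for weaker inhibition:
compound 1 `O=C(CN1CCN(c2nnc(Cc3ccncc3)c3ccccc23)CC1)Nc1cccc(F)c1` gives 4600 nM;
compound 2 `O=C(CN1CCN(c2nnc(Cc3ccccc3)c3ccccc23)CC1)Nc1ccc(F)c(C(F)(F)F)c1` gives 2480 nM;
compound 3 `O=C(CN1CCN(c2nnc(Cc3ccncc3)c3ccccc23)CC1)Nc1ccc(F)c(C(F)(F)F)c1` gives 16000 nM.

Compound 2 sits at the low end of these three numbers; its gap to compound 1 is within the scatter, and only its gap to compound 3, a 6.5-fold higher number from compound 2 to compound 3 (0.81 log units; beyond the scatter), lies beyond it.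

Compound 4 `O=C(CN1CCN(c2nnc(Cc3ccccc3)c3ccccc23)CC1)Nc1c(F)cccc1F` differs from compound 2 by 2,6-difluorophenyl in place of 4-fluoro-3-(trifluoromethyl)phenyl on an amide-type nitrogen. For the measured compounds named here, the one measured step on the same amide-type nitrogen is a 3.5-fold higher number from compound 1 to compound 3 (0.54 log units; beyond the scatter); no step towards a 2,6-difluorophenyl group exists here, so direction remains open. A modest shift, more likely upward than downward, is expected: a 1.8-fold higher number from compound 2 to compound 4 (0.26 log units; within the scatter). For compound 4 the estimate in this assay is 4500 nM, with a range from 1500 nM to 14000 nM.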

Compound 4, half-maximal inhibitory concentration: 84500 nM
The estimate for compound 4 lay 19-fold (1.27 log units) below the measured number; measured number outside the range, above it.
By their numbers in this assay, from the lowest: compounds 2 and 1 (each within the scatter of the next); then compound 3; then compound 4.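

In this assay, the group on the amide-type nitrogen proves able to carry a large step: 2,6-difluorophenyl in place of 4-fluoro-3-(trifluoromethyl)phenyl gives (a 34-fold higher number from compound 2 to compound 4 (1.53 log units; beyond the scatter)). For the compounds shown here, that exceeds the only earlier step at this nitrogen (a 3.5-fold higher number from compound 1 to compound 3 (0.54 log units; beyond the scatter)), so the position is more sensitive than that step suggested. Nothing available explains the size of the new step.

The two groups differ in more than one substituent, so the fluorine placement and the trifluoromethyl group cannot be separated. Going by these compounds, how a 2-fluorophenyl or an unsubstituted phenyl group would read on the same core remains open.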